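Chloro for trifluoromethyl on the aryl urea

A few compounds are considered here, and "the series" means these few. Any claim that something is new, unique, unknown or untested is made for them only; others in the source may bear on it.

Measured in a functional assay on MOLT-4 cells (Homo sapiens) for inhibition, read by MTT assay, with a stated time of 72 h (on this read-out lower numbers stand for stronger inhibition and higher numbers for weaker inhibition), so far:
- compound 1 `COc1cc(NC(C)CCCNC(=O)NNC(=O)Nc2ccc(F)cc2)c2ncccc2c1` gives >= 250000 nM as a limit of the assay
- compound 2 `COc1cc(NC(C)CCCNC(=O)Nc2ccc(C(F)(F)F)cc2)c2ncccc2c1` gives 20000 nM as a number

Among the compounds with values here, compound 2 holds the only actual number so far. Compound 3 `COc1cc(NC(C)CCCNC(=O)Nc2ccc(Cl)cc2)c2ncccc2c1` carries chloro in place of trifluoromethyl on an aromatic carbon, para to a large group (chloro in place of trifluoromethyl on an aromatic carbon). Within the data shown here, the one measured step is an at least 12-fold lower number from compound 1 to compound 2 (1.09 log units; beyond the scatter) and it concerns a far larger exchange at the same end of the molecule, so it sets no size for this one. No step beyond the scatter is expected in this assay and a 1.1-fold higher number from compound 2 to compound 3 (0.04 log units; within the scatter) is the estimated change. The expected value for compound 3 is 22000 nM with an estimated range from 8000 nM to 60000 nM around it.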

Compound 3, half-maximal inhibitory concentration: 24000 nM
Compound 3: the middle estimate sits 1.1-fold (0.04 log units) below what was measured; measured number inside the range.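

In this assay, exchanging trifluoromethyl for chloro on this aromatic carbon, para to a large group, gives a 1.2-fold higher number from compound 2 to compound 3 (0.08 log units; within the scatter), so the two groups cannot be told apart here. The large step seen with 4-(trifluoromethyl)phenyl recurs with 4-chlorophenyl: an at least 10-fold lower number from compound 1 to compound 3 (1.01 log units; beyond the scatter). That step rests on a limit for compound 1, not a number: the limit of >= 250000 nM in this assay, at which 1 of the 3 values shown sits.

Open, on these data alone, is whether an amine or a carboxylic acid on this aromatic carbon would move the number beyond the scatter. Also open, as far as these compounds go, is how a longer chain in the shared core would read in this assay.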